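This account rests on a few compounds, and the source may have more. Where it says the series, first, only, none or still open, it means among the compounds named here.

Working notes on the series. Compound 1 `CC1(/C=C/c2ccccc2)C=CC(=O)O1` gives > 1000000 nM in a functional assay on K562 cells (Homo sapiens) for inhibition, read by sulforhodamine B assay, with a stated time of 48 h (on this read-out higher numbers stand for weaker inhibition of growth and lower numbers for stronger inhibition of growth), and this is a limit of the assay, not a number. Among the compounds with values here, compound 2 `CC1(/C=C/c2ccc(C(F)(F)F)cc2)C=CC(=O)O1` gives 652000 nM in this assay, the only true number so far. Compound 3 `CC1(/C=C/c2ccc(F)cc2)C=CC(=O)O1` gives > 1000000 nM in this assay, and this too is only a limit. The series therefore sits against (the limit of > 1000000 nM in this assay, at which 2 of the 3 values shown sit), with compound 3 standing at that limit alongside compound 1.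

The next structure is compound 4 `CC1(/C=C/c2ccc(O)cc2)C=CC(=O)O1`, with hydroxy in place of fluoro on an aromatic carbon.

Within the data shown here, no measured step involves hydroxy. The nearest evidence comes from changes at the same place: an at least 1.5-fold lower number from compound 1 to compound 2 (0.18 log units; that floor lies within the scatter), a step that the two limits leave unreadable from compound 1 to compound 3 and an at least 1.5-fold higher number from compound 2 to compound 3 (0.18 log units; that floor lies within the scatter). None of these shows a readable change beyond the scatter, so no large move is expected in this assay.

An estimated step of an at least 1.2-fold lower number from compound 3 to compound 4 (0.09 log units; that floor lies within the scatter) is expected, which would mean no change beyond the scatter that can be established. For compound 4 the estimated value is 800000 nM, with an expected range of 350000 nM to 1000000 nM. A result reported only as a limit is also likely.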

Compound 4, concentration for total growth inhibition: > 1000000 nM
Compound 4 was reported as a limit; the forecaster's own chance of this, stated with the estimate: 60%; middle value at least 1.2-fold (0.09 log units) from the limit.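

Hydroxy enters at this position with a hydrogen-bond donor and a hydrogen-bond acceptor that fluoro does not have, yet compound 4 still reads only as a limit of the assay in this assay. Within the data shown here, the steps from compound 1 and from compound 3 to compound 4 cannot be read, as both ends of each are limits, and the one step that can be read, an at least 1.5-fold higher number from compound 2 to compound 4 (0.18 log units; that floor lies within the scatter), does not establish a difference between hydroxy and trifluoromethyl. The series now sits even more firmly against the top of the assay range: the limit of > 1000000 nM in this assay, at which 3 of the 4 values shown sit.

From the compounds shown here alone, with a true number for compound 2 alone, it remains open how far compound 1, compound 3 and compound 4 lie from that limit, and whether any change at this position moves growth inhibition beyond the scatter. Going by these compounds, how an amine or a carboxylic acid at this position would read in this assay also stays open, as does the effect of any change to the shared core.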